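N-Hydroxy to N-hydrogen on the pyridone of compound 2

The source may report more compounds than this note shows. Statements on the series, on what has been measured and on what is new or still open speak of the compounds shown alone.

Measured compounds:
- compound 1, `C/C=C\C[C@@H](C)C[C@@H](C)/C(O)=C1/C(=O)N/C(=C\c2ccc(O)cc2)C1=O`: > 40000 nM
- compound 2, `C=C[C@@H]1C[C@H](C)C[C@H](C)C1c1c(O)ccn(O)c1=O`: 1240 nM

Within the data shown here, in a functional assay on A549 cells (Homo sapiens) for inhibition, read by MTT assay, with a stated time of 48 h (on this read-out lower numbers stand for stronger inhibition and higher numbers for weaker inhibition), compound 2 gives 1240 nM, and this is the only number among the values shown. For compound 1 the assay reports a limit only, > 40000 nM, not a number; (the limit of > 40000 nM in this assay, at which 1 of the 2 values shown sits). Among the measured compounds shown here, no step between two measured compounds is available, so nothing measured constrains the size of a change on this core.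

Compound 3, `C=C[C@@H]1C[C@H](C)C[C@H](C)C1c1c(O)cc[nH]c1=O`, is still to be measured in this assay. It differs from compound 2 in one place: hydrogen in place of hydroxy on an aromatic nitrogen.

For the measured compounds named here, the single number for compound 2 offers no measured comparison for this kind of change, so the expectation rests on the structural change alone. A weaker inhibition in compound 3 than in compound 2 is expected, with a step from compound 2 to compound 3 of about a 4.8-fold higher number from compound 2 to compound 3 (0.68 log units; beyond the scatter), beyond the usual scatter but short of the limit. For compound 3 in this assay the estimate is 6000 nM, within 1500 nM to 30000 nM.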

Compound 3, half-maximal inhibitory concentration: > 40000 nM
Compound 3 ended at the assay's limit; the forecaster's own chance of this, stated with the estimate: 20%; middle value at least 6.6-fold (0.82 log units) from the limit.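

Among these compounds, this pair gives the first measured step on this core, and it places the hydroxy on the aromatic nitrogen as a position where the inhibition is highly sensitive to change: hydrogen in its place gives an at least 32-fold higher number from compound 2 to compound 3 (1.50 log units; beyond the scatter) in this assay, a large step beyond the scatter. Compound 3 gives only a limit of the assay, > 40000 nM, and not a number. The step therefore marks a lower bound, and its true size stays unread, since compound 3 reaches the same ceiling as compound 1 and any further loss would not register: the limit of > 40000 nM in this assay, at which 2 of the 3 values shown sit.

The compounds shown leave open whether the oxygen on the aromatic nitrogen is itself what matters, or whether a methoxy group or an amino group at that nitrogen would hold the value of compound 2, 1240 nM. They also leave open whether the same change has a comparable effect on the other core, that of compound 1, and whether the step seen in this assay carries over to any other read-out.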